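Swapping Methoxy for Chloro at the Assay Limit

This account rests on a few compounds, and the source may have more. Where it says the series, first, only, none or still open, it means among the compounds named here.

Of the compounds shown here, three sharing one core have been tested so far: compound 1 (`CCC(=O)Nc1ncc(-c2ccc(OC)cc2)n1C`), compound 2 (`COc1ccc(-c2cnc(NC(=O)c3ccn[nH]3)n2C)cc1`) and compound 3 (`COc1ccc(-c2cnc(NC(=O)c3ccccc3OC)n2C)cc1`). In a toxicity assay on THP-1 cells (Homo sapiens) for inhibition (a higher number here means that more compound is tolerated, a lower number that less compound is tolerated), compound 1 gives > 100000 nM, which is a limit of the assay and not a number. Compound 2 gives > 100000 nM, also a limit. Compound 3 gives > 100000 nM, again a limit. Compound 3 therefore stands where the other two stand, and the whole picture so far is the limit of > 100000 nM in this assay, at which 3 of the 3 values shown sit.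

The next compound, compound 4 (`COc1ccc(-c2cnc(NC(=O)c3ccccc3Cl)n2C)cc1`), carries chloro in place of methoxy on an aromatic carbon, ortho to a large group: chloro in place of methoxy on an aromatic carbon. The same difference can be read as 2-methoxyphenyl to 2-chlorophenyl.

The closest evidence comes from swaps of the group on the carbonyl carbon. Ethyl to 1H-pyrazol-5-yl is a step that the two limits leave unreadable from compound 1 to compound 2. Ethyl to 2-methoxyphenyl is a step that the two limits leave unreadable from compound 1 to compound 3. 1H-pyrazol-5-yl to 2-methoxyphenyl is a step that the two limits leave unreadable from compound 2 to compound 3. None of these has a readable size, but each one stayed at the limit, so no shift in either direction is expected in this assay. The expected change, no larger than the scatter, is a number no higher from compound 3 to compound 4 (the limit leaves the size open). For compound 4 the estimated value is 100000 nM, with an expected range from 50000 nM to 200000 nM.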

Compound 4, half-maximal cytotoxic concentration: > 50000 nM
Compound 4 ended at the assay's limit; the forecaster's own chance of this, stated with the estimate: 85%; the middle value is on the limit's open side.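

In this assay compound 4 gives > 50000 nM, which is a limit of the assay and not a number. Among the compounds shown here, no step to compound 4 from compound 1, compound 2 or compound 3 can be read, as all four values are limits. The compounds shown leave open how much of each compound these cells tolerate, and whether chloro in place of methoxy changes that at all.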